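This account rests on a few compounds, and the source may have more. Where it says the series, first, only, none or still open, it means among the compounds named here.

Measured so far:
- compound 1, `COc1cc2c(Oc3ccc(NC(=O)N/N=C/c4ccc(C(F)(F)F)cc4)cc3F)ccnc2cc1OCCCN1CCCCC1`: 1100 nM
- compound 2, `COc1cc2c(Oc3ccc(NC(=O)N/N=C/c4ccncc4)cc3F)ccnc2cc1OCCCN1CCCCC1`: 1400 nM

In a functional assay on MDA-MB-231 cells (Homo sapiens) for cytotoxicity, read by MTT assay, with a stated time of 72 h (a lower number here means a stronger inhibitor, a higher number a weaker inhibitor), compound 1 gives 1100 nM and compound 2 gives 1400 nM. Compound 2 cannot be set apart from compound 1 on these two numbers, since the step of a 1.3-fold higher number from compound 1 to compound 2 (0.10 log units; within the scatter) lies within the usual scatter of repeated measurements.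

Compound 3, `COc1cc2c(Oc3ccc(NC(=O)N/N=C/c4cc5ccccc5[nH]4)cc3F)ccnc2cc1OCCCN1CCCCC1`, is the next step from compound 2: 1H-indol-2-yl in place of pyridin-4-yl on a carbon with a double bond to nitrogen. Among the compounds with values here, the only measured step that bears on it is a 1.3-fold higher number from compound 1 to compound 2 (0.10 log units; within the scatter), which exchanged one aromatic group for another on the same carbon and changed nothing beyond the scatter. On that basis compound 3 is expected to give a number close to that of compound 2, and the estimated step of a 1.2-fold lower number from compound 2 to compound 3 (0.07 log units; within the scatter) is not expected to exceed the scatter. The estimate for compound 3 in this assay is 1200 nM, with a range from 400 nM to 3600 nM.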

Compound 3, half-maximal inhibitory concentration: 980 nM
Compound 3: the middle estimate sits 1.2-fold (0.09 log units) above what was measured, within the range that was stated.
By their numbers in this assay, from the lowest: compounds 3, 1 and 2 (each within the scatter of the next).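

This result widens what is known about the place on the carbon with a double bond to nitrogen. In this assay, replacing the single ring of pyridin-4-yl or 4-(trifluoromethyl)phenyl with the two-ring 1H-indol-2-yl, which also brings a hydrogen-bond donor, stays within the scatter: a 1.4-fold lower number from compound 2 to compound 3 (0.15 log units; within the scatter) and a 1.1-fold lower number from compound 1 to compound 3 (0.05 log units; within the scatter). Nothing available explains why these different groups cannot be told apart.

On these data alone, all three groups at this place are aromatic, so it remains open whether a cyclohexyl ring, a carboxylic acid or a short carbon chain with an amine at its end would give a similar number. As far as these compounds go, it is also open whether any group here can move the number beyond the scatter.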